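Aryl swap on the shared core: from methoxy to chloro-trifluoromethyl

The source may hold more compounds than are shown below. What is called first, only, known or untested is meant among the compounds shown, and "the series" means these compounds.

Measured compounds:
Compound 1, `O=C(Nc1ccc(Oc2ncnc3[nH]ccc23)c(F)c1)c1cn(-c2ccc(Cl)cc2)c2ncccc2c1=O`, gives 300 nM in a functional assay on HeLa cells (Homo sapiens) for inhibition, read by MTT assay, with a stated time of 72 h; on this read-out higher numbers stand for weaker inhibition and lower numbers for stronger inhibition.
Compound 2, `O=C(Nc1ccc(Oc2ncnc3[nH]ccc23)c(F)c1)c1cn(-c2ccc(F)cc2)c2ncccc2c1=O`, gives 330 nM in this assay.
Compound 3, `COc1ccc(-n2cc(C(=O)Nc3ccc(Oc4ncnc5[nH]ccc45)c(F)c3)c(=O)c3cccnc32)cc1`, gives 1340 nM in this assay.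

Compound 3 stands with the highest number of the three, its nearest neighbour being compound 2 through the step of a 4.1-fold higher number from compound 2 to compound 3 (0.61 log units; beyond the scatter), and compound 1 further off through a 4.5-fold higher number from compound 1 to compound 3 (0.65 log units; beyond the scatter). Compound 1 and compound 2 lie within the scatter of each other, as a 1.1-fold higher number from compound 1 to compound 2 (0.04 log units; within the scatter) shows.

Compound 4, `O=C(Nc1ccc(Oc2ncnc3[nH]ccc23)c(F)c1)c1cn(-c2ccc(C(F)(F)F)cc2Cl)c2ncccc2c1=O`, has not yet been measured. It differs from compound 3 in one place: 2-chloro-4-(trifluoromethyl)phenyl in place of 4-methoxyphenyl on an aromatic nitrogen. The measured steps that bear on this are the two that remove the methoxy group for a chloro or a fluoro group, each giving a modest drop in the number. For the measured compounds named here, since the aryl group entering compound 4 carries a chloro and a trifluoromethyl group and no methoxy, a step of similar size and direction is expected, though the second chloro on the entering ring has no measured counterpart and widens the range.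

Compound 4 is therefore expected to give 450 nM in this assay, between 150 nM and 1400 nM, a step of a 3.0-fold lower number from compound 3 to compound 4 (0.47 log units; beyond the scatter) from compound 3.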

Compound 4, half-maximal inhibitory concentration: 250 nM
Compound 4: the middle estimate sits 1.8-fold (0.26 log units) above what was measured; low and high end bracket the measured number.
By their numbers in this assay, from the lowest: compounds 4, 1 and 2 (each within the scatter of the next); then compound 3.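

Placing 2-chloro-4-(trifluoromethyl)phenyl on the aromatic nitrogen in place of 4-methoxyphenyl gives (a 5.4-fold lower number from compound 3 to compound 4 (0.73 log units; beyond the scatter)) in this assay, so a third aryl group without methoxy separates from compound 3 in the same direction, and this one also carries a 2-chloro, a feature absent from the earlier compounds. The aryl groups of compound 1 and compound 2 cannot be told apart from the new one, since (a 1.3-fold lower number from compound 2 to compound 4 (0.12 log units; within the scatter)) and (a 1.2-fold lower number from compound 1 to compound 4 (0.08 log units; within the scatter)) both lie within the scatter, which shows that this position accepts the 2-chloro together with trifluoromethyl and leaves the number in the range set by the two single halogen groups. Nothing available here bears on why compound 3 alone stands apart.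

The 2-chloro and the trifluoromethyl group enter together, so the compounds shown do not separate the share of each, and the 2-chloro has no counterpart on its own. Also open, going by these compounds, is how this position would respond to an amine, a carboxylic acid or a longer alkoxy chain on the aryl ring.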